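The compounds below may be only part of what the source reports. "The series", "measured", "known", "first", "only" and "open" are said of these compounds alone.

Of the compounds shown here, three of a shared core have been measured in an in vivo ADME assay on the whole organism for metabolic stability, with Mus musculus as the target, read by LC-MS, at a dose of 160 mg/kg by the oral route (a higher number here means that the compound lasts longer, a lower number that the compound disappears faster), and a fourth waits. Compound 1 `CC(C)/N=C(\NC1=NC(=O)CN1c1ccc(Cl)c(Cl)c1)Nc1ccc(Cl)c(Cl)c1` gives 0.454 h in this assay. Compound 3 `CN1CC(=O)N=C1NC(=N)Nc1ccc(Cl)c(Cl)c1` sits at a limit of this assay rather than at a number, reported as > 1 h; this is the upper limit (the limit of > 1 h in this assay, at which 1 of the 3 values shown sits). Compound 2 `CN1CC(=O)N=C1N/C(=N\C(=O)OC(C)(C)C)Nc1ccc(Cl)c(Cl)c1` also sits at a limit of this assay, reported as < 0.167 h, the lower limit (the limit of < 0.167 h in this assay, at which 1 of the 3 values shown sits). So compound 2 stands at the short end of what this assay can report, with one other compound at the far limit and compound 1 between them.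

Compound 4 `CC(C)(C)OC(=O)/N=C(\NC1=NC(=O)CN1C(C)(C)C)Nc1ccc(Cl)c(Cl)c1` is the compound still to be measured. It differs from compound 2 in one place: tert-butyl in place of methyl on an amine nitrogen in a ring. Among the compounds with values here, no measured pair in this set shares that change, so there is no measured step to lean on. The expectation is that the step from compound 2 to compound 4 in this assay, an at least 1.1-fold higher number from compound 2 to compound 4 (0.07 log units; that floor lies within the scatter), stays within the usual scatter of repeated measurements, with no clear direction. Compound 4 is therefore expected to give about 0.2 h in this assay, estimated to lie between 0.1 h and 0.6 h.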

Compound 4, half-life: < 0.167 h
Compound 4 ended at the assay's limit; the forecaster's own chance of this, stated with the estimate: 40%; middle value at least 1.1-fold (0.07 log units) away from the limit.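

Compound 2 and compound 4 both sit at the same limit of this assay, so no step can be read between them: the limit of < 0.167 h in this assay, at which 2 of the 4 values shown sit.

The compounds shown leave open whether tert-butyl in place of methyl on an amine nitrogen in a ring changes the half-life at all, and in which direction.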